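A few compounds are considered here, and "the series" means these few. Any claim that something is new, unique, unknown or untested is made for them only; others in the source may bear on it.

Measured in an in vitro functional assay on cells for antagonist activity at B1 bradykinin receptor (Homo sapiens), read by luminescence and calcium flux, with a stated time of 2 h; a higher number here means a weaker inhibitor, a lower number a stronger inhibitor:
Compound 1 `Cc1cc(S(=O)(=O)N2C=CNC(=O)[C@H]2CC(=O)N[C@H]2CCN(C)CC2(C)C)c(C)cc1Cl` gives 0.28 nM.
Compound 2 `Cc1cc(S(=O)(=O)N2C=CNC(=O)[C@H]2CC(=O)N2CCC[C@H](N3CCCC3)C2)c(C)cc1Cl` gives 38 nM.
Compound 3 `Cc1cc(S(=O)(=O)N2C=CNC(=O)[C@H]2CC(=O)N2CCCCC(N(C)C)CC2)c(C)cc1Cl` gives 4.75 nM.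

Compound 3 stands second highest of the three in this assay: compound 1 lies well below it, as a 17-fold higher number from compound 1 to compound 3 (1.23 log units; beyond the scatter) shows, while compound 2 lies above it, as an 8.0-fold lower number from compound 2 to compound 3 (0.90 log units; beyond the scatter) shows. Compound 4 `Cc1cc(S(=O)(=O)N2C=CNC(=O)[C@H]2CC(=O)N2CCC3(CCN(C)C3)C2)c(C)cc1Cl` differs from compound 3 by a group of 10 heavy atoms (8 carbon, 2 nitrogen; 2 five-membered non-aromatic rings with 1 hetero atom each) in place of a group of 11 heavy atoms (9 carbon, 2 nitrogen; one eight-membered non-aromatic ring with 1 hetero atom), on a carbonyl carbon. All three measured steps change the group on this carbonyl carbon, and they span a wide spread, with a 140-fold higher number from compound 1 to compound 2 (2.13 log units; beyond the scatter) the largest. The group entering compound 4 is close in atom count to the group of compound 1, but the spread among the measured groups makes a large step in either direction possible. Compound 4 is expected near the middle of the measured range, at 3 nM (range 0.4 nM to 25 nM), meaning an expected 1.6-fold lower number from compound 3 to compound 4 (0.20 log units; within the scatter).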

Compound 4, half-maximal inhibitory concentration: 1.53 nM
The estimate for compound 4 lay 2.0-fold (0.29 log units) above the measured number; the range from low to high includes it.
By their numbers in this assay, from the lowest: compound 1; then compound 4; then compound 3; then compound 2.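

On a carbonyl carbon, the group with 2 five-membered non-aromatic rings in compound 4 gives a stronger inhibitor in this assay than the group with one eight-membered non-aromatic ring (a 3.1-fold lower number from compound 3 to compound 4 (0.49 log units; beyond the scatter)) and the group of compound 2 (a 25-fold lower number from compound 2 to compound 4 (1.40 log units; beyond the scatter)), but the group of compound 1 remains stronger (a 5.5-fold higher number from compound 1 to compound 4 (0.74 log units; beyond the scatter)). Compound 2 and compound 4 each carry two rings in this group, so ring count alone does not set the number. Nothing shown explains these differences.

Still open, from the compounds shown here alone, is whether an open-chain amine or a group carrying a carboxylic acid on this carbonyl carbon would come close to compound 1.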